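A few compounds are considered here, and "the series" means these few. Any claim that something is new, unique, unknown or untested is made for them only; others in the source may bear on it.

In an assay for inhibition of protein disulfide-isomerase (Homo sapiens), with a stated time of 1 h (a lower number here means a stronger inhibitor, a higher number a weaker inhibitor), compound 1 `O=[N+]([O-])c1ccc(C(c2c(O)ccc3[nH]ncc23)N2CCCCC2)cc1` gives 520 nM. Compound 2 `Cc1ccnc(NC(c2ccc([N+](=O)[O-])cc2)c2ccc3cccnc3c2O)c1` gives 530 nM in this assay, a number that lies within the scatter of the value of compound 1, so the two compounds stand together on what has been measured. Compound 3 `Cc1ccnc(NC(c2ccc(C(F)(F)F)cc2)c2ccc3cccnc3c2O)c1` differs from compound 2 in one place: trifluoromethyl in place of nitro on an aromatic carbon. No measured pair tests this change, so nothing shown says which way it moves the number; a step in this assay that stays within the scatter, in either direction, is expected. Compound 3 is estimated at 700 nM, with a range of 250 nM to 2000 nM. This estimate means an expected step of a 1.3-fold higher number from compound 2 to compound 3 (0.12 log units; within the scatter).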

Compound 3, half-maximal inhibitory concentration: 26500 nM
For compound 3 the middle estimate is 38-fold (1.58 log units) below the measured one; measured number above the stated range.
By their numbers in this assay, from the lowest: compounds 1 and 2 (each within the scatter of the next); then compound 3.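

Putting trifluoromethyl in place of nitro on the aromatic carbon para to a large group is far from neutral in this assay: it gives a 50-fold higher number from compound 2 to compound 3 (1.70 log units; beyond the scatter). The number therefore depends strongly on the group at this place, which compound 1 and compound 2 could not show, as they differ in more than one place. Nothing shown explains the loss.

From the compounds shown here alone, whether a nitrile or a carboxylic acid at this place would match nitro stays open. So does whether the same change has a similar effect on the core of compound 1.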